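The source may report more compounds than this note shows. Statements on the series, on what has been measured and on what is new or still open speak of the compounds shown alone.

Working notes on the series.

Compound 1 `Nc1nc(Cl)c2ncn(Cc3ccccc3CCl)c2n1` carries the amino group that is absent from the other two measured compounds, compound 2 `ClCc1cccc(Cn2cnc3nc(Cl)nc(Cl)c32)c1` and compound 3 `ClCc1ccc(Cn2cnc3c(Cl)nc(Cl)nc32)cc1`. In a functional assay on ACHN cells (Homo sapiens) for cytotoxicity, read by sulforhodamine B assay, with a stated time of 48 h (a lower number here means a stronger inhibitor of growth, a higher number a weaker inhibitor of growth), compound 1 gives 5750 nM, the highest of the three numbers. Compound 3 gives 2340 nM in this assay, and compound 2 gives 1120 nM; both stand clearly lower than compound 1, beyond the usual scatter. Among the measured compounds shown here, neither pair with compound 1 differs in a single place, so no step is computed and only the raw values can be compared.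

Compound 4 `ClCc1ccccc1Cn1cnc2c(Cl)ncnc21` differs from compound 1 in one place: hydrogen in place of amino on an aromatic carbon. For the measured compounds named here, the change removes the one donor that compound 1 has on its core and leaves the rest untouched.

Going by the values given here, no measured step tests this change directly. The two compounds that lack the amino group both show lower numbers than compound 1, but each also carries a second chloro group, so their values give only indirect support. A modest move toward lower numbers is expected, with a fair chance the step stays within the scatter.

Compound 4 is estimated at 3200 nM in this assay, with a plausible range from 1200 nM to 8500 nM, which corresponds to an expected step of a 1.8-fold lower number from compound 1 to compound 4 (0.25 log units; within the scatter).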

Compound 4, concentration for 50% growth inhibition: 2700 nM
Compound 4: middle estimate off by 1.2-fold (0.07 log units), on the high side; low and high end bracket the measured number.
By their numbers in this assay, from the lowest: compound 2; then compounds 3 and 4 (each within the scatter of the next); then compound 1.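

Through the single change of hydrogen in place of amino on an aromatic carbon, between two ring nitrogen atoms, this assay gives a 2.1-fold lower number from compound 1 to compound 4 (0.33 log units; beyond the scatter), and this is the first direct reading at this position, since the earlier compounds each differ from compound 1 in more than one place. The step is modest but lies beyond the scatter, so the amino group at this position is not required for growth inhibition in these cells, and its removal goes with a lower number in this pair. Nothing measured on these compounds accounts for the step, and the reason for it remains unexplained.

As far as these compounds go, only one replacement at this position can be read so far, so it remains open whether a methylamino, hydroxyl or methoxy group there would move the number in the same direction. From the compounds shown here alone, a chloro group at this position, with the rest of compound 1 unchanged, also remains open, as compound 2 and compound 3 cannot separate that change from their other differences.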